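Trading a benzyl for an ester arm on a weak core

This account rests on a few compounds, and the source may have more. Where it says the series, first, only, none or still open, it means among the compounds named here.

Measured compounds:
- compound 1, `CCOC(=O)CN(Cc1ccccc1)c1nc(NCc2ccccc2)ncc1[N+](=O)[O-]`: > 100000 nM
- compound 2, `CCOC(=O)CNc1nc(NCc2ccccc2)ncc1[N+](=O)[O-]`: 74400 nM

In a functional assay on A549 cells (Homo sapiens) for antiproliferative activity, read by MTT assay, with a stated time of 48 h (a lower number here means a stronger inhibitor, a higher number a weaker inhibitor), compound 1 gives only > 100000 nM, which is a limit of the measurement rather than a number (the limit of > 100000 nM in this assay, at which 1 of the 2 values shown sits). Compound 2 gives 74400 nM in this assay. For the measured compounds named here, the one measured step, an at least 1.3-fold lower number from compound 1 to compound 2 (0.12 log units; that floor lies within the scatter), removes a benzyl from a nitrogen on the shared core and cannot be told apart from repeat-to-repeat scatter.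

Compound 3, `CCOC(=O)CNc1ncc([N+](=O)[O-])c(N(CC(=O)OCC)Cc2ccccc2)n1`, differs from compound 1 by ethoxycarbonyl in place of phenyl on a saturated chain carbon bound to a nitrogen on an aromatic ring. This exchange is not the same as the measured step, though both touch the substituents on the ring nitrogens and neither measured compound shows meaningful activity. Going by the values given here, no measured pair shows the replacement of a phenyl by an ethoxycarbonyl, so the expectation rests on the weakness of both compound 1 and compound 2. Compound 3 is therefore expected to stay near the limit, with a step of a number no higher from compound 1 to compound 3 (the limit leaves the size open) at most, and its value in this assay is estimated at 100000 nM within a range from 40000 nM to 300000 nM.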

Compound 3, half-maximal inhibitory concentration: > 100000 nM
Compound 3 ended at the assay's limit; the forecaster's own chance of this, stated with the estimate: 55%; the middle value sits exactly at the limit.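

In this assay compound 3 gives > 100000 nM as a limit of the assay, not a number. For the compounds shown here, compound 1 also stands at a limit, so no step between compound 1 and compound 3 can be read: the limit of > 100000 nM in this assay, at which 2 of the 3 values shown sit. The compounds shown leave open whether ethoxycarbonyl in place of phenyl changes antiproliferative activity at all.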